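This account rests on a few compounds, and the source may have more. Where it says the series, first, only, none or still open, it means among the compounds named here.

In a functional assay on MCF7 cells (Homo sapiens) for antiproliferative activity, read by MTT assay, with stated times of 24 h and 72 h (on this read-out higher numbers stand for weaker inhibition and lower numbers for stronger inhibition), compound 1 `COc1cc(N2C(=O)[C@@H](Oc3ccccc3)[C@H]2c2ccc(C#N)cc2)cc(OC)c1OC` gives 31600 nM while compound 2 `COc1cc(N2C(=O)[C@@H](Oc3ccccc3)[C@H]2c2ccc3ccccc3c2)cc(OC)c1OC` gives 282000 nM and compound 3 `COc1cc(N2C(=O)[C@@H](Oc3ccccc3)[C@H]2c2cccc3ccccc23)cc(OC)c1OC` gives 53000 nM on the same read-out. Compound 3 thus sits level with compound 1 at the lower end of the three numbers and well under compound 2. Compound 4 `COc1cc(N2C(=O)[C@@H](Oc3ccccc3)[C@H]2c2ccc(SC)cc2)cc(OC)c1OC` has 4-(methylsulfanyl)phenyl in place of naphthalen-1-yl on a saturated ring carbon. Among the compounds with values here, two measured steps bear on this: naphthalen-1-yl in place of 4-cyanophenyl stayed inside the scatter (a 1.7-fold higher number from compound 1 to compound 3 (0.22 log units; within the scatter)) and naphthalen-2-yl in its place gave a modest rise (an 8.9-fold higher number from compound 1 to compound 2 (0.95 log units; beyond the scatter)). Within the data shown here, no large step is therefore expected in this assay and any drift should lean toward the lower number of compound 1 (31600 nM). The expected step is small (a 1.5-fold lower number from compound 3 to compound 4 (0.18 log units; within the scatter)). For compound 4 the estimated value is 35000 nM with an expected range from 8000 nM to 130000 nM in this series.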

Compound 4, half-maximal inhibitory concentration: 7700 nM
Beside the measured number, compound 4's estimate is 4.5-fold (0.66 log units) above it; the whole stated range lies above it.
By their numbers in this assay, from the lowest: compound 4; then compounds 1 and 3 (each within the scatter of the next); then compound 2.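

At this saturated ring carbon, in this assay, 4-(methylsulfanyl)phenyl gives the lowest number of the series, with a 6.9-fold lower number from compound 3 to compound 4 (0.84 log units; beyond the scatter) and a 37-fold lower number from compound 2 to compound 4 (1.56 log units; beyond the scatter). Methylsulfanyl in place of cyano on an aromatic carbon gives a 4.1-fold lower number from compound 1 to compound 4 (0.61 log units; beyond the scatter), so exchanging one group on the aromatic ring is enough to move the number beyond the scatter. Nothing available here accounts for these steps.

As far as these compounds go, whether the drop depends on the sulfur atom remains open, and a methoxy group or a methyl group on the same aromatic carbon would address that. From the compounds shown here alone, how an amine there would read also remains open.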